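The source may hold more compounds than are shown below. What is called first, only, known or untested is meant among the compounds shown, and "the series" means these compounds.

Measured compounds:
Compound 1 `C#CCCOC(=O)c1ccc(C(CC)(CC)c2ccc(OCCC(O)(CC)CC)c(C)c2)n1CC`; in a functional assay on PC-3 cells (Homo sapiens) for antiproliferative activity, read by MTT assay, with a stated time of 48 h (a lower number here means a stronger inhibitor, a higher number a weaker inhibitor), compound 1 gives > 50000 nM, which is a limit of the assay.
Compound 2 `CCn1c(C(=O)Nc2ccc(OC(F)(F)F)cc2)ccc1C(CC)(CC)c1ccc(OCCC(O)(CC)CC)c(C)c1`; in this assay compound 2 gives > 50000 nM, also a limit of the assay.
Compound 3 `CCC(C)C(NC(=O)c1ccc(C(CC)(CC)c2ccc(OCCC(O)(CC)CC)c(C)c2)n1CC)C(=O)O`; in this assay compound 3 gives 13800 nM.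

Compound 1 thus stands only at a limit, and it shares that position with one other value, namely (the limit of > 50000 nM in this assay, at which 2 of the 3 values shown sit). The step to compound 4 `CCn1c(C(=O)NC(CO)CCO)ccc1C(CC)(CC)c1ccc(OCCC(O)(CC)CC)c(C)c1` changes (a group of 7 heavy atoms (4 carbon, 1 nitrogen, 2 oxygen; no ring) in place of a group of 5 heavy atoms (4 carbon, 1 oxygen; no ring), on a carbonyl carbon). Two measured steps start from the same carbonyl carbon of compound 1 and therefore bear on it: a step that the two limits leave unreadable from compound 1 to compound 2, which the two limits leave unreadable, and an at least 3.6-fold lower number from compound 1 to compound 3 (0.55 log units; beyond the scatter). Within the data shown here, the only change at this carbonyl carbon that brought a readable number put (1-carboxy-2-methylbutyl)amino in place of (but-3-yn-1-yl)oxy; compound 4 instead gains an amide-type substituent with no common name, so the guidance is thin. Compound 4 is expected to land at the limit or only a little beneath it, the estimated step being an at least 1.6-fold lower number from compound 1 to compound 4 (0.22 log units; that floor lies within the scatter). The estimate for compound 4 in this assay is 30000 nM, with a range from 8000 nM to 100000 nM.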

Compound 4, half-maximal inhibitory concentration: 8760 nM
Compound 4: middle estimate off by 3.4-fold (0.53 log units), on the high side; measured number inside the range.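

In this assay, a second substituent on this carbonyl carbon now gives a readable number, and 3-hydroxy-1-(hydroxymethyl)propyl on the amide-type nitrogen carries no carboxylic acid, so a readable number here does not depend on the acid of compound 3 (the step is an at least 5.7-fold lower number from compound 1 to compound 4 (0.75 log units; beyond the scatter)). The two readable amides cannot be told apart (a 1.6-fold lower number from compound 3 to compound 4 (0.20 log units; within the scatter)), so 1-carboxy-2-methylbutyl and 3-hydroxy-1-(hydroxymethyl)propyl serve alike on that nitrogen within this small set. The amide link alone does not account for the gain, as the choice of substituent on the same nitrogen still matters (an at least 5.7-fold lower number from compound 2 to compound 4 (0.75 log units; beyond the scatter)), with 4-(trifluoromethoxy)phenyl on the losing side.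

Going by these compounds, the true size of the steps that start from compound 1 or compound 2 stays open, and the steps between those two cannot be read, as both compounds stand at a limit rather than at a number: the limit of > 50000 nM in this assay, at which 2 of the 4 values shown sit. Also open, on these data alone, is whether a simple amine, a single hydroxyl on a longer chain or a plain alkyl amide on this carbonyl carbon would give a number in the same region as compound 3 and compound 4.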